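This account rests on a few compounds, and the source may have more. Where it says the series, first, only, none or still open, it means among the compounds named here.

In an ADME assay on the whole organism (plasma, Macaca fascicularis) for protein binding, read by LC-MS, using equilibrium dialysis and cassette dosing, with a stated time of 24 h, at a dose of 1 mg/kg by the oral route (a lower number here means a smaller unbound share, a higher number a larger unbound share of the compound), compound 1 `CCCCN(c1nc2ccccc2o1)[C@H](C)c1ccc(-c2ccccc2-c2nnn[nH]2)cc1` gives 0.000713. Compound 2 `CCCCN(c1nc2c(NC(C)=O)cccc2o1)[C@H](C)c1ccc(-c2ccccc2-c2nnn[nH]2)cc1` carries an acetamido group on the shared core, and in this assay compound 2 gives 0.00102. Among the compounds with values here, the only step in hand, a 1.4-fold higher number from compound 1 to compound 2 (0.16 log units; within the scatter), shows that adding this group left the unbound share essentially where it was. Within the data shown here, compound 2 stands at the top of the two numbers known, but only by a gap to compound 1 that lies within the scatter, so the two are not distinguished. Compound 3 `CCCCN(c1nc2c(C(=O)N(C)C)cccc2o1)[C@H](C)c1ccc(-c2ccccc2-c2nnn[nH]2)cc1` differs from compound 2 by dimethylcarbamoyl in place of acetamido on an aromatic carbon. Among the measured compounds shown here, the single measured step bears on this change only loosely, since one small group is exchanged for another at the same place rather than added; its size, within the scatter, gives no reason to expect a shift beyond the scatter here either. Compound 3 is therefore expected to show a step of a 1.1-fold higher number from compound 2 to compound 3 (0.03 log units; within the scatter). Compound 3 is estimated at 0.0011, with a range from 0.0005 to 0.0025.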

Compound 3, unbound fraction: 0.00411
Beside the measured number, compound 3's estimate is 3.7-fold (0.57 log units) below it, outside the stated range (above it).
By their numbers in this assay, from the lowest: compounds 1 and 2 (each within the scatter of the next); then compound 3.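

At this aromatic carbon, the choice of group matters in this assay: dimethylcarbamoyl in place of acetamido gives a clear change (a 4.0-fold higher number from compound 2 to compound 3 (0.61 log units; beyond the scatter)), so the earlier small step did not hold for every group here. Dimethylcarbamoyl in place of hydrogen also gives a change beyond the scatter (a 5.8-fold higher number from compound 1 to compound 3 (0.76 log units; beyond the scatter)), whereas acetamido in place of hydrogen did not. The two groups differ in their hydrogen-bond donors and heavy atoms, but no measurement here ties the shift to either difference.

As far as these compounds go, what a primary carboxamide, a carboxylic acid or an amine would do at this same carbon stays open. From the compounds shown here alone, whether dimethylcarbamoyl would give a similar step elsewhere on the shared core also remains open.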